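The compounds below may be only part of what the source reports. "The series", "measured", "known", "first", "only" and "open" are said of these compounds alone.

In a functional assay on CHO cells for positive allosteric modulation of metabotropic glutamate receptor 2 (Homo sapiens), read by scintillation counting and GTPgammaS binding, with a stated time of 30 min (on this read-out lower numbers stand for an effect already at smaller amounts and higher numbers for an effect only at larger amounts of compound), compound 1, with the structure `COc1ccc(-c2ccn(CCC(C)C)c(=O)c2C#N)cc1`, gives 1150 nM. Compound 2, `CC(C)CCn1ccc(-c2ccc(OCC3CC3)cc2)c(C#N)c1=O`, gives 290 nM, and compound 3, `CNc1ccc(-c2ccn(CCC(C)C)c(=O)c2C#N)cc1`, gives 460 nM. Two measured steps exceed the scatter: a 4.0-fold lower number from compound 1 to compound 2 (0.60 log units; beyond the scatter) and a 2.5-fold lower number from compound 1 to compound 3 (0.40 log units; beyond the scatter). The third does not: a 1.6-fold higher number from compound 2 to compound 3 (0.20 log units; within the scatter). Compound 3 therefore sits between the other two numbers, separated from compound 1 beyond the scatter and from compound 2 within it.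

Compound 4, `Cc1ccc(Oc2ccc(-c3ccn(CCC(C)C)c(=O)c3C#N)cc2)c(C)n1`, differs from compound 3 in one place: (2,6-dimethylpyridin-3-yl)oxy in place of methylamino on an aromatic carbon. Among the compounds with values here, the steps that bear on this are the one from compound 1 to compound 3 and the one from compound 2 to compound 3, since both swap an oxygen-linked group against the methylamino group at the same position. Enlarging the oxygen-linked group from methoxy to cyclopropylmethoxy lowered the number in the step from compound 1 to compound 2, and the cyclopropylmethoxy compound and the methylamino compound lie within the scatter of each other. A still larger oxygen-linked group is expected to give a number near or somewhat below that of compound 3, so for compound 4 the expected step is a 1.8-fold lower number from compound 3 to compound 4 (0.26 log units; within the scatter), with an estimate of 250 nM and a range from 70 nM to 900 nM.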

Compound 4, half-maximal effective concentration: 100 nM
Beside the measured number, compound 4's estimate is 2.5-fold (0.40 log units) above it, and the stated range covers the measured number.
By their numbers in this assay, from the lowest: compound 4; then compounds 2 and 3 (each within the scatter of the next); then compound 1.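

On an aromatic carbon para to a large group, the (2,6-dimethylpyridin-3-yl)oxy group brings a second aromatic ring to this position, and replacing methylamino with it gives a 4.6-fold lower number from compound 3 to compound 4 (0.66 log units; beyond the scatter) in this series. Within the data shown here, on the oxygen, the fall seen on going from methyl to cyclopropylmethyl continues, since 2,6-dimethylpyridin-3-yl in place of cyclopropylmethyl gives a 2.9-fold lower number from compound 2 to compound 4 (0.46 log units; beyond the scatter) and in place of methyl gives a 12-fold lower number from compound 1 to compound 4 (1.06 log units; beyond the scatter) as the only large step so far. Among these compounds, compound 4 is thus the first compound here set apart beyond the scatter from all the others, with the lowest number of the four.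

Going by these compounds, whether the two methyl groups or the ring nitrogen matter stays open, as does the result for a plain phenyl ring on the oxygen. No measurement at hand gives a reason for these steps.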